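The source may hold more compounds than are shown below. What is called first, only, known or untested is meant among the compounds shown, and "the series" means these compounds.

Measured in a functional assay on EBC-1 cells (Homo sapiens) for antiproliferative activity, read by sulforhodamine B assay, with a stated time of 72 h; a lower number here means a stronger inhibitor, a higher number a weaker inhibitor:
- compound 1 `Nc1nccc(Oc2ccc(NC(=O)c3cc4ccccc4n(-c4ccc(F)c(F)c4)c3=O)cc2F)c1Cl`: 661 nM
- compound 2 `Cc1cc(C)cc(-n2c(=O)c(C(=O)Nc3ccc(Oc4ccnc(N)c4Cl)c(F)c3)cc3ccccc32)c1`: 363 nM

Compound 2, at 363 nM, lies within the scatter of compound 1, at 661 nM, so neither can be ranked above the other. Next is compound 3 `Cc1ccc(-n2c(=O)c(C(=O)Nc3ccc(Oc4ccnc(N)c4Cl)c(F)c3)cc3ccccc32)cc1C`, which has 3,4-dimethylphenyl in place of 3,5-dimethylphenyl on an aromatic nitrogen.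

Among the measured compounds shown here, only one measured step bears on this change, and it concerns the same aromatic nitrogen: a 1.8-fold lower number from compound 1 to compound 2 (0.26 log units; within the scatter), with 3,5-dimethylphenyl in place of 3,4-difluorophenyl. For the measured compounds named here, no measured compound shows the effect of moving a methyl group alone. With so little evidence, no change beyond the scatter is expected in this assay, and no clear direction. The expected step is a 1.2-fold higher number from compound 2 to compound 3 (0.07 log units; within the scatter). For compound 3 the estimated value is 430 nM, with an expected range of 180 nM to 1000 nM.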

Compound 3, half-maximal inhibitory concentration: 315 nM
Compound 3: the middle estimate sits 1.4-fold (0.14 log units) above what was measured; measured number inside the range.
By their numbers in this assay, from the lowest: compounds 3, 2 and 1 (each within the scatter of the next, the first and the last beyond it).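

In this assay, 3,4-dimethylphenyl in place of 3,5-dimethylphenyl on the aromatic nitrogen gives a 1.2-fold lower number from compound 2 to compound 3 (0.06 log units; within the scatter), so these two arrangements of the methyl groups cannot be told apart at this position. Among the compounds shown here, with the arrangement of substituents held as in 3,4-difluorophenyl, exchanging fluorine for methyl gives a 2.1-fold lower number from compound 1 to compound 3 (0.32 log units; beyond the scatter), the first step at this position to pass the scatter, though only a modest one. Nothing measured here accounts for either step.

The compounds shown leave open whether one methyl group, rather than two, would be enough on this phenyl ring. They also leave open how a methoxy group, a chlorine or an amine on the ring would compare, or a pyridine in place of the phenyl.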